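The source may report more compounds than this note shows. Statements on the series, on what has been measured and on what is new or still open speak of the compounds shown alone.

Values measured in a functional assay on MCF7 cells (Homo sapiens) for antiproliferative activity, read by MTT assay, with a stated time of 48 h; a lower number here means a stronger inhibitor, a higher number a weaker inhibitor:

- Compound 1 `N=C(N)N/N=C(/C=C/c1ccccc1)c1ccccc1`: 17000 nM
- Compound 2 `Cc1ccc(/C=C/C(=N/NC(=N)N)c2ccccc2)cc1`: 16000 nM
- Compound 3 `N=C(N)N/N=C(/C=C/c1ccccc1F)c1ccccc1`: 3900 nM

Compound 3 has the lowest number of the three, which makes it the strongest inhibitor so far. Its lead is clear on both sides, with a 4.4-fold lower number from compound 1 to compound 3 (0.64 log units; beyond the scatter) and a 4.1-fold lower number from compound 2 to compound 3 (0.61 log units; beyond the scatter).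

The next compound, compound 4 `N=C(N)N/N=C(/C=C/c1ccccc1Cl)c1ccccc1`, changes one group of compound 3: chloro in place of fluoro on an aromatic carbon. Put simply, this is chloro in place of fluoro on an aromatic carbon, ortho to a large group.

The closest evidence is the fluoro step itself, a 4.4-fold lower number from compound 1 to compound 3 (0.64 log units; beyond the scatter), which shows a modest gain from adding fluoro in place of hydrogen. Adding methyl in place of hydrogen did much less, with a 1.1-fold lower number from compound 1 to compound 2 (0.03 log units; within the scatter). Among the compounds with values here, no measured compound carries chloro, so the data do not directly show what this swap will do. Compound 4 still has a single-atom group in the place that fluoro held, so it is expected to stay close to compound 3, with no step beyond the scatter. The expected change is a 1.2-fold higher number from compound 3 to compound 4 (0.06 log units; within the scatter). For compound 4 the estimated value is 4500 nM, with an expected range from 1800 nM to 12000 nM.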

Compound 4, half-maximal inhibitory concentration: 4200 nM
Estimate against measurement, compound 4: 1.1-fold (0.03 log units) above, and the stated range covers the measured number.
By their numbers in this assay, from the lowest: compounds 3 and 4 (each within the scatter of the next); then compounds 2 and 1 (each within the scatter of the next).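

In this assay, swapping fluoro for chloro at this aromatic carbon, ortho to a large group, leaves the number within the scatter, a 1.1-fold higher number from compound 3 to compound 4 (0.03 log units; within the scatter), while chloro in place of hydrogen gives a 4.0-fold lower number from compound 1 to compound 4 (0.61 log units; beyond the scatter), so the gain seen with fluoro is not unique to that one halogen. The 2-chlorophenyl group also keeps a lead beyond the scatter over the 4-methylphenyl group, a 3.8-fold lower number from compound 2 to compound 4 (0.58 log units; beyond the scatter), although that comparison changes both the group and where it sits on the ring. No measurement is available that explains why fluoro and chloro give such similar results here.

The compounds shown leave open whether this position accepts only halogens or also other groups, such as bromo, methoxy, trifluoromethyl or an amine, and whether a methyl placed ortho to a large group would match the halogens. They also leave open whether chloro or fluoro would give the same gain on the other phenyl ring of the shared core.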